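Adding a Second Chlorine to a Weakly Cytotoxic Purine

The source may hold more compounds than are shown below. What is called first, only, known or untested is meant among the compounds shown, and "the series" means these compounds.

Compound 1, `ClCc1cccc(Cn2cnc3ncnc(Cl)c32)c1`: 3460 nM in a functional assay on SF-268 cells (Homo sapiens) for cytotoxicity, read by sulforhodamine B assay, with a stated time of 48 h; a lower number here means a stronger inhibitor of growth, a higher number a weaker inhibitor of growth
Compound 2, `ClCc1ccccc1Cn1cnc2ncnc(Cl)c21`: 24500 nM
Compound 3, `ClCc1cccc(Cn2cnc3nc(Cl)nc(Cl)c32)c1`: 3800 nM

Compound 3 comes from compound 1 through one change, (chloro in place of hydrogen on an aromatic carbon), and that change produced a 1.1-fold higher number from compound 1 to compound 3 (0.04 log units; within the scatter), so the two numbers cannot be told apart. Compound 2 is built from the same atoms as compound 1, joined differently; the difference between the two cores is not broken down here. In this assay compound 2 stands clearly higher than compound 1 and compound 3, meaning it is a weaker inhibitor of growth than either.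

Compound 4, `ClCc1ccccc1Cn1cnc2nc(Cl)nc(Cl)c21`, has not been measured. Among the measured compounds shown here, it comes from compound 2 through (chloro in place of hydrogen on an aromatic carbon), the same change, at the same kind of place, as the one from compound 1 to compound 3. Its step is expected to be a 1.1-fold higher number from compound 2 to compound 4 (0.04 log units; within the scatter), set beside the earlier 1.1-fold higher number from compound 1 to compound 3 (0.04 log units; within the scatter), because that earlier step a 1.1-fold higher number from compound 1 to compound 3 (0.04 log units; within the scatter) stayed within the scatter. Compound 4 is therefore expected to give about 27000 nM, likely between 12000 nM and 60000 nM.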

Compound 4, concentration for total growth inhibition: 24500 nM
For compound 4 the middle estimate is 1.1-fold (0.04 log units) above the measured one, and the stated range covers the measured number.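

In this assay, putting a chloro group on the aromatic carbon between two ring nitrogen atoms gives no change at the digits printed from compound 2 to compound 4 (within the scatter), and the same change reads alike on the two cores: the same change on two cores in this assay, a 1.1-fold higher number (0.04 log units; within the scatter) from compound 1 to compound 3 and no change at the digits printed (within the scatter) from compound 2 to compound 4, 1.1-fold (0.04 log units) apart, within the scatter of two such steps. Within these two pairs, then, the change carries over from the core of compound 1 to the core of compound 2, in the sense that neither pair shows a step that can be told from ordinary repeat variation. This does not show that the chloro group would leave the number unchanged on any other core or in any other cell line, and it offers no explanation of why the two steps agree, since two pairs in one assay can support only a narrow statement.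

The compounds shown leave open what a different group at that same place, such as an amine or a longer carbon chain, would do to the number. They also leave open whether such a group would behave alike on both cores.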